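Methoxy on compound 2: expected step

This account rests on a few compounds, and the source may have more. Where it says the series, first, only, none or still open, it means among the compounds named here.

In a functional assay on HepG2 cells (Homo sapiens) for cytotoxicity, read by MTT assay, with a stated time of 48 h (a lower number here means a stronger inhibitor, a higher number a weaker inhibitor), compound 2 `COc1ccc(/C=C/C(=O)/C=C/c2nc3ccccc3n2C)cc1O` gives 2900 nM and lies within the scatter of compound 1 `COc1cc(/C=C/C(=O)/C=C/c2nc3cc([N+](=O)[O-])ccc3n2C)ccc1O` at 3700 nM in the same read-out. Compound 3 `COc1ccc(/C=C/C(=O)/C=C/c2nc3c(C)cccc3n2C)cc1O` gives 14700 nM and lies beyond the scatter from compound 2.

For the measured compounds named here, the next compound is compound 4 `COc1ccc2c(c1)nc(/C=C/C(=O)/C=C/c1ccc(OC)c(O)c1)n2C` and its only difference from compound 2 is methoxy in place of hydrogen on an aromatic carbon in words methoxy in place of hydrogen on an aromatic carbon. Going by the values given here, the one measured step of a similar kind is a 5.1-fold higher number from compound 2 to compound 3 (0.70 log units; beyond the scatter) for methyl in place of hydrogen on an aromatic carbon, a modest rise. Among the compounds with values here, compound 1 at 3700 nM also carries an added group on the core and shows no separation from compound 2, but it differs in more than one place and gives no clean step. The two precedents together suggest a rise smaller than the methyl step. The expected step is a 1.7-fold higher number from compound 2 to compound 4 (0.24 log units; within the scatter) toward a higher number. For compound 4 the estimated value is 5000 nM with an expected range from 1800 nM to 14000 nM.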

Compound 4, half-maximal inhibitory concentration: 4200 nM
The estimate for compound 4 lay 1.2-fold (0.08 log units) above the measured number, and the stated range covers the measured number.
By their numbers in this assay, from the lowest: compounds 2, 1 and 4 (each within the scatter of the next); then compound 3.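

In this assay, methoxy in place of hydrogen on an aromatic carbon gives a 1.4-fold higher number from compound 2 to compound 4 (0.16 log units; within the scatter). This position, meta to a fused ring and para to a fused ring, therefore accepts methoxy with no separation from the unsubstituted parent, whereas the earlier clean step, a 5.1-fold higher number from compound 2 to compound 3 (0.70 log units; beyond the scatter), came from methyl at a different place on the core. An added group on this ring does not by itself go with a higher number, but those two steps differ in both group and place, so neither difference can be singled out.

Nothing available here bears on the reason for either step. Still open, going by these compounds, is how this position responds to an amine or a carboxylic acid, and whether methoxy at the methyl-bearing place of compound 3 would give a similar step.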